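The source may hold more compounds than are shown below. What is called first, only, known or untested is meant among the compounds shown, and "the series" means these compounds.

Measured in a functional assay on the whole organism for antagonist activity, with Mus musculus as the target, in the maximal electroshock model; on this read-out lower numbers stand for an effect already at smaller amounts and higher numbers for an effect only at larger amounts of compound:
- compound 1 `COC(=O)NC1=NC(c2cccc(F)c2)CN1`: 70 mg/kg
- compound 2 `COC(=O)NC1=NC(c2cccc(Cl)c2)CN1`: 48 mg/kg

Within the data shown here, the only measured step on this read-out is a 1.5-fold lower number from compound 1 to compound 2 (0.16 log units; within the scatter), chloro in place of fluoro on an aromatic carbon. It lies within the scatter, so compound 2 stands level with compound 1 and not clearly apart from it.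

Compound 3 `CC(C)OC(=O)NC1=NC(c2cccc(Cl)c2)CN1` differs from compound 2 by isopropyl in place of methyl on an oxygen next to a carbonyl group. Among the measured compounds shown here, the one measured step lies at a different place, so it gives no direct size for this change, and the data hold no other guide. No shift beyond the scatter is therefore expected in this assay, and no direction is favoured, although the uncertainty is wide.

Compound 3 is expected at 50 mg/kg, with an estimated range of 20 mg/kg to 130 mg/kg. This estimate means an expected 1.0-fold higher number from compound 2 to compound 3 (0.02 log units; within the scatter).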

Compound 3, dose for half-maximal effect: 79 mg/kg
Estimate against measurement, compound 3: 1.6-fold (0.20 log units) below, within the range that was stated.
By their numbers in this assay, from the lowest: compounds 2, 1 and 3 (each within the scatter of the next).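

Isopropyl in place of methyl on an oxygen next to a carbonyl group is the only change shown at this position, and it gives a 1.6-fold higher number from compound 2 to compound 3 (0.22 log units; within the scatter) in this assay. The earlier pair varied only the halogen on the aromatic carbon, whereas this step shows that a group of 3 heavy atoms can replace one of 1 heavy atom on this oxygen while compound 3 stays level with compound 2. Nothing available offers an explanation for this result.

As far as these compounds go, it remains open whether a longer chain, such as n-butyl, or a benzyl group on this oxygen would also stay within the scatter of compound 2. From the compounds shown here alone, it is also open whether an amine in place of this oxygen would keep the effect in this assay.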